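Adding a nitro group to compound 1

The compounds below may be only part of what the source reports. "The series", "measured", "known", "first", "only" and "open" are said of these compounds alone.

Going by the values given here, in a functional assay on HO8910 cells (Homo sapiens) for inhibition, read by MTT assay, with a stated time of 24 h, tested at 100 ug/mL (on this read-out lower numbers stand for less inhibition of growth and higher numbers for more inhibition of growth at the one concentration tested), compound 1 (`O=C(CCCCC(S)CCS)Nc1ccccc1`) gives 13.7% and holds the only number. Compound 2 (`O=C(CCCCC(S)CCS)Nc1ccccc1Cl`) is reported as "not active" (no number reported) with no number. Compound 3 (`Cc1cccc(NC(=O)CCCCC(S)CCS)c1`) is likewise reported as "not active" (no number reported) with no number. Compound 4 (`O=C(CCCCC(S)CCS)Nc1ccc([N+](=O)[O-])cc1`) differs from compound 1 by nitro in place of hydrogen on an aromatic carbon, para to a large group (nitro in place of hydrogen on an aromatic carbon). Among the compounds with values here, no measured pair shows the size of any single change, so in this assay no step beyond the scatter is expected, in either direction. The estimated change (a number 0.3 percentage points higher from compound 1 to compound 4 (within the scatter)) stays within the scatter. A report without a number also remains possible. For compound 4 the estimated value is 14% (expected range 3% to 30%).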

Compound 4, percent growth inhibition at one concentration: 51.2%
The estimate for compound 4 lay 37.2 percentage points below the measured number; measured number outside the range, above it.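

In this assay, going by these compounds alone, nitro in place of hydrogen on an aromatic carbon, para to a large group, gives a number 37.5 percentage points higher from compound 1 to compound 4 (beyond the scatter) and is the only step that can be read. This place on the ring therefore responds to substitution, which the entries without a number for compound 2 and compound 3 could not show; their steps cannot be read. No measurement shown here bears on the origin of this step.

From the compounds shown here alone, whether an amine or a carboxylic acid at this same place would give a step of similar size remains open. Also open, going by these compounds, is whether nitro needs this particular place on the ring.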